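Series notes: acid ceramidase inhibitors, step from compound 2 to compound 4

The compounds below may be only part of what the source reports. "The series", "measured", "known", "first", "only" and "open" are said of these compounds alone.

Measured so far:
compound 1 `CN1CCc2oc(=O)n(C(=O)NCCCCc3ccccc3)c2C1` 516 nM
compound 2 `CN1CCC(c2ccc3c(c2)oc(=O)n3C(=O)NCCOCc2ccccc2)CC1` 215 nM
compound 3 `O=C(NCCCCc1ccccc1)n1c(=O)oc2cnccc21` 3 nM

All three numbers come from an assay on HEK293 cells for inhibition of acid ceramidase (Homo sapiens), read by fluorescence, with stated times of 10 min and 3 h; a lower number here means a stronger inhibitor, a higher number a weaker inhibitor. Compound 2 holds the second highest of the three numbers. Compound 1 lies higher and compound 3 lies far lower; both gaps to compound 2 are beyond the scatter of this assay. Compound 3 stands apart from the other two by a wide margin.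

Compound 4 `CN1CCC(c2ccc3c(c2)oc(=O)n3C(=O)NCCCCc2ccccc2)CC1` has not been measured in this assay. It differs from compound 2 in one place: phenethyl in place of benzyloxy on a saturated chain carbon, two bonds along the chain from an amide-type nitrogen. Going by the values given here, the 4-phenylbutyl chain of compound 4 is the one carried by compound 1 and compound 3, but the cores of those two differ from the core shared by compound 2 and compound 4, so no step between measured compounds tells what this change does on its own.

Expectation: a step from compound 2 toward a lower number is estimated, of about a 1.8-fold lower number from compound 2 to compound 4 (0.25 log units; within the scatter), which may not exceed the scatter. For compound 4 the estimated value in this assay is 120 nM, with a range from 40 nM to 400 nM.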

Compound 4, half-maximal inhibitory concentration: 129 nM
Beside the measured number, compound 4's estimate is 1.1-fold (0.03 log units) below it; measured number inside the range.
By their numbers in this assay, from the lowest: compound 3; then compounds 4 and 2 (each within the scatter of the next); then compound 1.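

Going by these compounds alone, this is the first step between measured compounds that differ in one place: in this assay, phenethyl in place of benzyloxy on a saturated chain carbon, two bonds along the chain from an amide-type nitrogen, gives a 1.7-fold lower number from compound 2 to compound 4 (0.22 log units; within the scatter). On the shared core, this position therefore does not separate the two groups. One hydrogen-bond acceptor leaves and none enters, yet this pair gives no sign that the acceptor matters in this assay. Nothing measured here bears on the reason for this result.

The compounds shown leave open whether the same change reads the same on the core of compound 1 or the core of compound 3. They also leave open how a longer chain, or a chain ending in an amine or a carboxylic acid, would stand at this position.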